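Ether side chain isomer on the shared core

The source may hold more compounds than are shown below. What is called first, only, known or untested is meant among the compounds shown, and "the series" means these compounds.

compound 1 `CC#CCCOc1cccc2ccc(N)nc12` — > 2000 nM
compound 2 `Nc1ccc2cccc(OCC3CC4CCC3C4)c2n1` — 137 nM
compound 3 `Nc1ccc2cccc(OC3CCCCCC3)c2n1` — 137 nM

In an assay on cells with melanin-concentrating hormone receptor 1 (Homo sapiens) as the target, read by radioligand binding (a higher number here means a weaker inhibitor, a lower number a stronger inhibitor), compound 2 gives 137 nM. Compound 3 gives 137 nM in this assay; the two values lie within the scatter of each other, so no order between them can be read. For compound 1 only a limit is recorded in this assay, > 2000 nM, which is a limit of the assay and not a number; it is the limit of > 2000 nM in this assay, at which 1 of the 3 values shown sits. Compound 1 therefore stands at the weak end of what is shown, without a number of its own.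

Compound 4 `CCC#CCOc1cccc2ccc(N)nc12` has not yet been measured in this assay. It differs from compound 1 in one place: but-1-yn-1-yl in place of but-2-yn-1-yl on a saturated chain carbon bound to an oxygen on an aromatic ring. The same atoms are joined differently; the open chain at the oxygen stays, while compound 2 and compound 3, the two with numbers, carry ring groups there instead. Among the measured compounds shown here, no step between two measured compounds is recorded, so the data give no size for a change of this kind. The expectation is of no step beyond the scatter: a step that the limit leaves unreadable from compound 1 to compound 4. For compound 4 the estimate in this assay is 3000 nM, with a range from 800 nM to 12000 nM, and a limit rather than a number is expected to be at least as likely as a number.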

Compound 4, half-maximal inhibitory concentration: > 2000 nM
Compound 4: only a limit was reported (the forecaster's own chance of this, stated with the estimate: 60%); the middle value lies beyond the limit too.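

In this assay compound 1 and compound 4 both stand at a limit of the assay and not at a number, so no step can be read between them, because the change of but-2-yn-1-yl to but-1-yn-1-yl ends at the same limit: the limit of > 2000 nM in this assay, at which 2 of the 4 values shown sit.

The compounds shown leave open whether this change of chain alters binding in this assay at all.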